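The source may report more compounds than this note shows. Statements on the series, on what has been measured and on what is new or still open speak of the compounds shown alone.

Compound 1 `COc1cc(NC(=O)Nc2cc(Nc3ccc(OC)c(C)c3)ncn2)cc(OC)c1`: in a functional assay on HCC827 cells (Homo sapiens) for inhibition, read by MTT assay, with a stated time of 48 h, tested at 10 uM (on this read-out lower numbers stand for less inhibition and higher numbers for more inhibition at the one concentration tested (going by the name of the read-out)), compound 1 gives 48.3%.
Compound 2 `COc1cc(NC(=O)Nc2cc(Nc3ccc(Br)cc3OC)ncn2)cc(OC)c1`: in this assay compound 2 gives 57.7%.
Compound 3 `COc1cc(NC(=O)Nc2cc(Nc3cc(I)ccc3OC)ncn2)cc(OC)c1`: in this assay compound 3 gives 71%.

All three compounds share one core and differ only in the aryl group carried on a nitrogen on an aromatic ring. Compound 3 stands highest of the three numbers: the step of a number 13.3 percentage points higher from compound 2 to compound 3 (beyond the scatter) and the step of a number 22.7 percentage points higher from compound 1 to compound 3 (beyond the scatter) both lie beyond the scatter, while the step of a number 9.4 percentage points higher from compound 1 to compound 2 (within the scatter) does not.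

Compound 4 `COc1cc(NC(=O)Nc2cc(Nc3ccc(C(C)(C)C)cc3)ncn2)cc(OC)c1` is not yet measured. It changes the same position: 4-(tert-butyl)phenyl in place of 5-iodo-2-methoxyphenyl on a nitrogen on an aromatic ring.

The three measured steps all concern swaps of this aryl group, and they ranged from a change within the scatter to a modest rise. Going by the values given here, no measured pair shows a group resembling 4-(tert-butyl)phenyl, so the direction can only be guessed from the spread of the three numbers. Among the compounds with values here, since compound 3 holds the highest value and every change at this position so far moved the number by a modest amount, a modest fall back toward the region of compounds 1 and 2 is the expected outcome, with an expected step of a number 16 percentage points lower from compound 3 to compound 4 (beyond the scatter) in this assay. Compound 4 is therefore estimated at 55%, within a range from 35% to 75%.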

Compound 4, a percentage reported as inhibition, at one concentration (the size of the read-out at that concentration, not a potency): 32.7%
For compound 4 the middle estimate is 22.3 percentage points above the measured one, outside the stated range (below it).
By their numbers in this assay, from the lowest: compound 4; then compounds 1 and 2 (each within the scatter of the next); then compound 3.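

In this assay, replacing the aryl group gives a number 38.3 percentage points lower from compound 3 to compound 4 (beyond the scatter), the largest step yet seen at this position, so the choice of group on this nitrogen can move the number much further than the earlier swaps suggested. Going by these compounds alone, compound 4 also sits clearly apart from the other two, with a number 25 percentage points lower from compound 2 to compound 4 (beyond the scatter) and a number 15.6 percentage points lower from compound 1 to compound 4 (beyond the scatter), which places it lowest of the four and makes it the only one whose aryl group has no methoxy. No measurement shown here explains this fall.

The swap from compound 3 to compound 4 removes the methoxy and the iodine and adds the tert-butyl in a single change, so the compounds shown cannot separate the contribution of each. Also open, from the compounds shown here alone, is how the number would respond to an unsubstituted phenyl, which would carry none of these groups, or to an aryl group bearing an amine or a carboxylic acid.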